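The compounds below may be only part of what the source reports. "The series", "measured", "known", "first", "only" and "open" are said of these compounds alone.

For the measured compounds named here, in a functional assay on A549 cells (Homo sapiens) for antiproliferative activity, read by MTT assay, with a stated time of 48 h (a lower number here means a stronger inhibitor, a higher number a weaker inhibitor), compound 1 `CCN(CC)Cc1ccc2c(c1O)-c1ccc(cc1O)CCc1ccc(O)c(c1)Oc1ccc(cc1)CC2` gives 5740 nM, the higher of the two exact numbers measured so far. Compound 2 `Oc1ccc2cc1Oc1ccc(cc1)CCc1ccc(CN3CCCC3)c(O)c1-c1ccc(cc1O)CC2` gives 2260 nM. Compound 3 `Oc1ccc2cc1Oc1ccc(cc1)CCc1ccc(CN3CCN(Cc4ccccc4)CC3)c(O)c1-c1ccc(cc1O)CC2` gives > 20000 nM, which is a limit of the assay and not a number. Compound 4 `CN1CCN(Cc2ccc3c(c2O)-c2ccc(cc2O)CCc2ccc(O)c(c2)Oc2ccc(cc2)CC3)CC1` keeps the core of compound 1 and changes one group: 4-methylpiperazin-1-yl in place of diethylamino on a saturated chain carbon bound to an aromatic carbon. Going by the values given here, the only measured step at this place, a 2.5-fold lower number from compound 1 to compound 2 (0.40 log units; beyond the scatter), is modest, so a step of no more than similar size is expected in this assay. Compound 3, with its limit of > 20000 nM, tilts the expected direction towards a higher number. The expected change is a 1.4-fold higher number from compound 1 to compound 4 (0.14 log units; within the scatter). For compound 4 the estimate is 8000 nM, with an expected range of 3000 nM to 20000 nM.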

Compound 4, half-maximal inhibitory concentration: 5590 nM
Estimate against measurement, compound 4: 1.4-fold (0.16 log units) above; low and high end bracket the measured number.
By their numbers in this assay, from the lowest: compound 2; then compounds 4 and 1 (each within the scatter of the next). At a limit, above all of these: compound 3.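

In this assay, the ring-bearing 4-methylpiperazin-1-yl group performs like open-chain diethylamino, with a 1.0-fold lower number from compound 1 to compound 4 (0.01 log units; within the scatter), while pyrrolidin-1-yl keeps its edge, with a 2.5-fold higher number from compound 2 to compound 4 (0.39 log units; beyond the scatter). So a ring at this place does not by itself decide the outcome. The far end of the piperazine does matter, with hydrogen in place of phenyl on a saturated chain carbon bound to an amine nitrogen in a ring giving an at least 3.5-fold lower number from compound 3 to compound 4 (0.55 log units; beyond the scatter), a step that rests on a limit for compound 3 and not on a number: the limit of > 20000 nM in this assay, at which 1 of the 4 values shown sits.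

Going by these compounds, whether piperidin-1-yl or morpholin-4-yl on this carbon would side with compound 2 or with compounds 1 and 4 remains open.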